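Amide variation on the shared core: toward compound 3

The compounds below may be only part of what the source reports. "The series", "measured", "known", "first", "only" and "open" are said of these compounds alone.

Measured so far:
compound 1 `CN(C(=O)CCc1ccccc1)c1ccc2[nH]c(-c3n[nH]c4ccccc34)cc2n1`: 20900 nM
compound 2 `CN(C(=O)c1ccc(Cl)cc1)c1ccc2[nH]c(-c3n[nH]c4ccccc34)cc2n1`: 2420 nM

In a functional assay on SMMC-7721 cells (Homo sapiens) for antiproliferative activity, read by MTT assay, with a stated time of 72 h (on this read-out higher numbers stand for weaker inhibition and lower numbers for stronger inhibition), compound 2 stands lowest of the two numbers recorded; its nearest neighbour is compound 1, and the step of an 8.6-fold lower number from compound 1 to compound 2 (0.94 log units; beyond the scatter) lies beyond the scatter. Among the compounds with values here, that is the only step in hand, and it compares phenethyl with 4-chlorophenyl on the carbonyl carbon, not 4-chlorophenyl with furan-2-yl.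

Compound 3 `CN(C(=O)c1ccco1)c1ccc2[nH]c(-c3n[nH]c4ccccc34)cc2n1` is the next member. It differs from compound 2 in one place: furan-2-yl in place of 4-chlorophenyl on a carbonyl carbon.

Within the data shown here, the single measured step bears on this change only loosely. It shows that the group on the carbonyl carbon can move the number in this assay by a modest amount, but it gives no direct read on an exchange of one aromatic ring for another. With nothing else to lean on, a small step is expected for compound 3 in this assay, more likely toward a higher number than a lower one, and possibly within the scatter; the expected step is a 1.7-fold higher number from compound 2 to compound 3 (0.22 log units; within the scatter).

For compound 3 the estimate in this assay is 4000 nM, with a range from 1500 nM to 12000 nM.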

Compound 3, half-maximal inhibitory concentration: 28200 nM
Compound 3: middle estimate off by 7.1-fold (0.85 log units), on the low side, and the stated range ends below it.
By their numbers in this assay, from the lowest: compound 2; then compounds 1 and 3 (each within the scatter of the next).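

In this assay the group on the carbonyl carbon moves the number even when one aromatic ring replaces another: a 12-fold higher number from compound 2 to compound 3 (1.07 log units; beyond the scatter), so an aromatic ring at this place does not by itself give the lower number, and furan-2-yl goes against any such reading. Phenethyl and furan-2-yl cannot be told apart here, with a 1.3-fold higher number from compound 1 to compound 3 (0.13 log units; within the scatter), so among these three groups only 4-chlorophenyl stands apart, and compound 2 has steps beyond the scatter to both other compounds. Nothing at hand gives a measured reason for the gap between 4-chlorophenyl and furan-2-yl.

Still open, from the compounds shown here alone, is whether the lower number of compound 2 goes with the chlorine or with the six-membered carbon ring, a question that a plain phenyl on the same carbonyl carbon would address. Also open, going by these compounds, is how this assay would read for other groups on this carbonyl carbon, such as a saturated amine, a carboxylic acid or a longer carbon chain.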